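The source may report more compounds than this note shows. Statements on the series, on what has been measured and on what is new or still open speak of the compounds shown alone.

Of the compounds shown here, three built on one shared core have been measured in an ADME assay on HEK293 cells (Homo sapiens) for cytotoxicity, read by resazurin assay, with a stated time of 48 h; a lower number here means that less compound is tolerated, a higher number that more compound is tolerated. Compound 1, `C=Cc1ccc(S(=O)(=O)Nc2ccc3oc(-c4ccccc4)nc3c2)cc1`, gives 53000 nM. Compound 3, `O=S(=O)(Nc1ccc2oc(-c3ccccc3)nc2c1)c1ccc(C(F)(F)F)cc1`, gives 74000 nM. Compound 2, `O=S(=O)(Nc1ccc(-c2nc3ccccc3o2)cc1)c1cccc(O)c1`, gives > 100000 nM, which is a limit of the assay rather than a number. Among the compounds with values here, for compound 2 the only information is the limit of > 100000 nM in this assay, at which 1 of the 3 values shown sits. Among the two numbers shown, compound 1 stands at the lower one, and the step of a 1.4-fold higher number from compound 1 to compound 3 (0.14 log units; within the scatter) keeps compound 3 within the scatter of compound 1, so the two cannot be separated.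

Compound 4, `COc1ccc(Cl)cc1S(=O)(=O)Nc1ccc2oc(-c3ccccc3)nc2c1`, has not yet been measured. It differs from compound 1 in one place: 5-chloro-2-methoxyphenyl in place of 4-vinylphenyl on a sulfonyl sulfur. Within the data shown here, the only measured step available for comparison is a 1.4-fold higher number from compound 1 to compound 3 (0.14 log units; within the scatter), which also exchanges one group for another on the same kind of ring and stayed within the scatter. Among the measured compounds shown here, no measured compound carries a 5-chloro-2-methoxyphenyl, so the data give no direct guide to it. The expectation is therefore a step of no more than the scatter in this assay, in no firm direction. Compound 4 is expected to give 60000 nM, within a range from 30000 nM to 120000 nM. That estimate means an expected step of a 1.1-fold higher number from compound 1 to compound 4 (0.05 log units; within the scatter).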

Compound 4, half-maximal cytotoxic concentration: 74000 nM
The estimate for compound 4 lay 1.2-fold (0.09 log units) below the measured number; the range from low to high includes it.
By their numbers in this assay, from the lowest: compounds 1, 3 and 4 (each within the scatter of the next). At a limit, above all of these: compound 2.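

The step of a 1.4-fold higher number from compound 1 to compound 4 (0.14 log units; within the scatter) in this assay involves more than the earlier exchange of one group on the ring. The whole 4-vinylphenyl gives way to 5-chloro-2-methoxyphenyl, bringing in oxygen, chlorine and a hydrogen-bond acceptor. Even so, the two numbers cannot be separated, so two quite different aromatic groups on the sulfonyl sulfur, those of compound 3 and compound 4, have now each stayed within the scatter of compound 1, a statement that holds for these three compounds only. Nothing measured here explains why this exchange leaves the number so close, and the step itself is too small to be given a cause.

Still open, as far as these compounds go, is whether any group at this position can move the number beyond the scatter in this assay, for example an amine or a carboxylic acid on the ring, or a plain alkyl chain in place of the ring on the sulfonyl sulfur. Within the data shown here, also open is which of the two new substituents, the chlorine or the methoxy group, would matter on its own, as the only compound carrying them has both together.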